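This account rests on a few compounds, and the source may have more. Where it says the series, first, only, none or still open, it means among the compounds named here.

Measured in a functional assay on HCT-116 cells (Homo sapiens) for antiproliferative activity, read by MTT assay, with a stated time of 72 h; on this read-out higher numbers stand for weaker inhibition and lower numbers for stronger inhibition:
- Compound 1 `O=C(CCc1cccc2c1B(O)OC2)NCc1ccccc1`: > 100000 nM (a limit of the assay, not a number)
- Compound 2 `Cc1ccc(NC(=O)CCc2cccc3c2B(O)OC3)cc1`: 4500 nM
- Compound 3 `C#Cc1ccc(NC(=O)CCc2cccc3c2B(O)OC3)cc1`: 45000 nM

Of the two values that are true numbers, compound 3 holds the higher one in this assay. Its nearest neighbour is compound 2, at 4500 nM.

The next structure, compound 4 `O=C(CCc1cccc2c1B(O)OC2)Nc1ccc(-c2ccccc2)cc1`, has phenyl in place of ethynyl on an aromatic carbon, para to a large group (phenyl in place of ethynyl on an aromatic carbon). Among the compounds with values here, no measured step makes this exact swap, so the evidence is indirect. The closest guide is a 10-fold higher number from compound 2 to compound 3 (1.00 log units; beyond the scatter), which changed the group at this same place, with ethynyl in place of methyl. It shows that a swap here can move the number well beyond the scatter. The other guide is an at least 22-fold lower number from compound 1 to compound 2 (1.34 log units; beyond the scatter), with 4-methylphenyl in place of benzyl on an amide-type nitrogen. Compound 4 keeps a ring bonded directly to that nitrogen, as compound 2 does.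

A modest move toward compound 2 therefore seems likelier than no move, though the direction is uncertain. The expected change is a 3.0-fold lower number from compound 3 to compound 4 (0.48 log units; beyond the scatter). For compound 4 the estimated value is 15000 nM, with an expected range from 3000 nM to 70000 nM.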

Compound 4, half-maximal inhibitory concentration: 13000 nM
The estimate for compound 4 lay 1.2-fold (0.06 log units) above the measured number; the range from low to high includes it.
By their numbers in this assay, from the lowest: compound 2; then compound 4; then compound 3. At a limit, above all of these: compound 1.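

Swapping ethynyl for phenyl in this assay gives a 3.5-fold lower number from compound 3 to compound 4 (0.54 log units; beyond the scatter), even though phenyl brings 6 heavy atoms and an aromatic ring where ethynyl has 2 heavy atoms and no ring. The number therefore does not simply climb with the size of the group on this aromatic carbon: the rise from methyl to ethynyl might have suggested that it would, but compound 4 goes against that reading. Phenyl still does not match methyl, as the comparison shows a 2.9-fold higher number from compound 2 to compound 4 (0.46 log units; beyond the scatter), so among the three groups on this carbon, methyl gives the lowest number, phenyl an intermediate one and ethynyl the highest.

The compounds shown leave open how a methoxy group, an amine or a carboxylic acid on this same carbon would compare with these three groups, and whether the order would hold for them. The data given offer no measured explanation of why phenyl lies between methyl and ethynyl.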